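Amine swap on the fused core: compound 3 to compound 4

The compounds below may be only part of what the source reports. "The series", "measured", "known", "first", "only" and "open" are said of these compounds alone.

Measured so far:
compound 1 `CN(C)c1ncnc2c1ncn2Cc1ccc(Cl)cc1` — 0%
compound 2 `CN(C)c1ncnc2c1ncn2C` — 30%
compound 3 `c1nc(N2CCCCC2)c2ncn(CC3CC3)c2n1` — 28%

In a functional assay on the whole organism for inhibition, with Rattus norvegicus as the target, at a dose of 25 mg/kg by the intraperitoneal route (a higher number here means more inhibition at the dose given (going by the name of the read-out), a lower number less inhibition), compound 1 gives 0%, compound 2 gives 30% and compound 3 gives 28%. Compound 3 stands second highest of the three numbers; its nearest neighbour is compound 2, whose number lies within the scatter of it, so no order between those two can be read. Compound 1 lies furthest away, with a number beyond the scatter below that of compound 3.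

Compound 4 `c1nc(NC2CCC2)c2ncn(CC3CC3)c2n1` is not yet measured. It differs from compound 3 in one place: cyclobutylamino in place of piperidin-1-yl on an aromatic carbon. Going by the values given here, none of the measured compounds form a pair differing in only one place, so there is no measured step to guide the direction or size of this change; the three numbers rest on different cores and different substituents at once.

For compound 4 the expectation is a modest drop or no change beyond the scatter, an estimated step of a number 8 percentage points lower from compound 3 to compound 4 (within the scatter). Compound 4 is estimated at 20%, in the range 5% to 40%.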

Compound 4, a percentage reported as inhibition, in the whole organism at one dose (the size of the read-out at that dose, not a potency): 0%
Estimate against measurement, compound 4: 20 percentage points above, outside the stated range (below it).
By their numbers in this assay, from the lowest: compounds 1 and 4 (each within the scatter of the next); then compounds 3 and 2 (each within the scatter of the next).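

Going by these compounds alone, the amine on this aromatic carbon matters at this dose: in this assay the change to cyclobutylamino from piperidin-1-yl is a number 28 percentage points lower from compound 3 to compound 4 (beyond the scatter) and gives the first one-place comparison. The shared core and the rest of the structure stay the same, so the step belongs to this exchange alone. The exchange alters several things at once, as a four-membered carbon ring with a hydrogen-bond donor replaces a six-membered ring with a hetero atom and no donor, and no measurement here explains the step.

As far as these compounds go, whether ring size or the donor goes with the step remains open. N-methylcyclobutylamino would keep the four-membered ring without the donor, while cyclohexylamino would keep a six-membered ring with the donor.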